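Formyl to Methyl on a Weakly Cytotoxic Core

The source may hold more compounds than are shown below. What is called first, only, known or untested is meant among the compounds shown, and "the series" means these compounds.

The account begins with compound 1 `CC1(C)CCC[C@]2(C)[C@@H](/C=C/C3=CCOC3=O)C(C=O)=CC(=O)[C@@H]12`. In a functional assay on HeLa cells (Homo sapiens) for inhibition, read by sulforhodamine B assay (a lower number here means that less compound is tolerated, a higher number that more compound is tolerated), compound 1 gives > 100000 nM, which is a limit of the assay and not a number. Compound 1 thus stands at the limit of > 100000 nM in this assay, at which 1 of the 2 values shown sits. The only other measured compound, compound 2 `C=C1CC[C@H]2C(C)(C)CCC[C@]2(C)[C@H]1C/C=C1/CC(O)OC1=O`, gives 60600 nM in this assay; no step between compound 2 and compound 1 is shown, and their two values show only that compound 2 reaches a number where compound 1 does not.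

Compound 3 `CC1=CC(=O)[C@H]2C(C)(C)CCC[C@]2(C)[C@H]1/C=C/C1=CCOC1=O` differs from compound 1 in a single place: methyl in place of formyl on a double-bonded ring carbon. Among the measured compounds shown here, with compound 1 known only as a limit, no measured step in this assay sets the size of such a change, and the expected step is small, in no firm direction: an at least 1.2-fold lower number from compound 1 to compound 3 (0.09 log units; that floor lies within the scatter). Compound 3 is therefore estimated at 80000 nM, within a range of 30000 nM to 300000 nM.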

Compound 3, concentration lethal to 50% of the cells: > 100000 nM
Compound 3 was reported as a limit; the forecaster's own chance of this, stated with the estimate: 50%; middle value at least 1.2-fold (0.09 log units) from the limit.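

In this assay, among the compounds shown here, compound 3, like compound 1, is reported only as a limit of the assay, so no step between compound 1 and compound 3 can be read: the limit of > 100000 nM in this assay, at which 2 of the 3 values shown sit. The compounds shown leave open how far, and in which direction, methyl in place of formyl on a double-bonded ring carbon moves the number in this assay.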